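From phenyl to thiophen-2-yl on a sulfonyl sulfur

The compounds below may be only part of what the source reports. "The series", "measured", "known", "first", "only" and "open" are said of these compounds alone.

compound 1 `CC(C)CS(=O)(=O)N[C@@H](CNC(=O)c1ccc2c(c1)C(=O)N(CCC1CCNCC1)C2)C(=O)O` with 9 nM
compound 2 `CCCCCC(=O)N[C@@H](CNC(=O)c1ccc2c(c1)C(=O)N(CCC1CCNCC1)C2)C(=O)O` with 13 nM
compound 3 `O=C(NC[C@H](NS(=O)(=O)c1ccccc1)C(=O)O)c1ccc2c(c1)C(=O)N(CCC1CCNCC1)C2` with 8 nM

In a functional assay for inhibition, with Homo sapiens as the target (a lower number here means a stronger inhibitor, a higher number a weaker inhibitor), compound 3 gives 8 nM and sits within the scatter of both other compounds, so the three cannot be ranked. Compound 4 `O=C(NC[C@H](NS(=O)(=O)c1cccs1)C(=O)O)c1ccc2c(c1)C(=O)N(CCC1CCNCC1)C2` carries thiophen-2-yl in place of phenyl on a sulfonyl sulfur.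

Among the compounds with values here, three measured steps bear on this change. Isobutyl to phenyl on the same sulfonyl sulfur gave a 1.1-fold lower number from compound 1 to compound 3 (0.05 log units; within the scatter) and is the closest comparison. Pentylcarbonyl to phenylsulfonyl on the amine nitrogen gave a 1.6-fold lower number from compound 2 to compound 3 (0.21 log units; within the scatter) and the reverse kind of swap from the isobutylsulfonyl compound gave a 1.4-fold higher number from compound 1 to compound 2 (0.16 log units; within the scatter) in the same test. All three stayed within the scatter, and none of these compounds goes against that. Within the data shown here, no measured compound carries thiophen-2-yl, so what follows is an extrapolation. Even so, no step beyond the scatter is expected in this assay in either direction. The expected change is no change at the digits printed from compound 3 to compound 4 (within the scatter) on this estimate. For compound 4 the estimated value is 8 nM with 4 nM to 16 nM as the expected range.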

Compound 4, half-maximal inhibitory concentration: 7 nM
Beside the measured number, compound 4's estimate is 1.1-fold (0.06 log units) above it, within the range that was stated.
By their numbers in this assay, from the lowest: compounds 4, 3, 1 and 2 (each within the scatter of the next).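

In this assay, within the data shown here, thiophen-2-yl in place of phenyl on the sulfonyl sulfur gives a 1.1-fold lower number from compound 3 to compound 4 (0.06 log units; within the scatter) and so shows that this position accepts a five-membered aromatic ring containing sulfur, where the earlier compounds offered only a six-membered ring of carbon and open chains. The comparisons with those chains read the same way, with thiophen-2-yl in place of isobutyl giving a 1.3-fold lower number from compound 1 to compound 4 (0.11 log units; within the scatter) and (thiophen-2-yl)sulfonyl in place of pentylcarbonyl on the amine nitrogen giving a 1.9-fold lower number from compound 2 to compound 4 (0.27 log units; within the scatter) in the same test, so all four groups now stand within the scatter of the compounds they were compared with here. No measurement is at hand that could explain why these different groups read alike.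

Still open, from the compounds shown here alone, is whether this tolerance would hold for a naphthyl group, a pyridyl ring, or a phenyl ring carrying a carboxylic acid or an amine on the sulfonyl sulfur. Also open, going by these compounds, is how the test would respond to a change in the shared core, which is the same in all four compounds.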